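This account rests on a few compounds, and the source may have more. Where it says the series, first, only, none or still open, it means among the compounds named here.

In an ADME assay on HepG2 cells (Homo sapiens) for inhibition, read by fluorescence and resazurin assay, with a stated time of 72 h (on this read-out higher numbers stand for weaker inhibition and lower numbers for stronger inhibition), compound 2 (`Brc1ccc(Nc2nccc(Nc3ccc4cn[nH]c4c3)n2)cc1`) gives 20000 nM. Compound 1 (`NS(=O)(=O)c1ccc(Nc2nccc(Nc3ccc4cn[nH]c4c3)n2)cc1`) gives 22000 nM, within the scatter of compound 2, while compound 3 (`CN1CCN(c2cccc(Nc3nccc(Nc4ccc5cn[nH]c5c4)n3)c2)CC1`) gives a clearly lower 6700 nM. Compound 4 (`Cc1ccc(Nc2nccc(Nc3ccc4cn[nH]c4c3)n2)cc1`) differs from compound 2 by a single exchange, (methyl in place of bromo on an aromatic carbon), with methyl in place of bromo on an aromatic carbon. Within the data shown here, only one measured step bears on this carbon: bromo in place of sulfamoyl, which gave a 1.1-fold lower number from compound 1 to compound 2 (0.04 log units; within the scatter). That step stayed within the scatter, so no step beyond the scatter is expected in this assay here. The expected change is a 1.1-fold lower number from compound 2 to compound 4 (0.05 log units; within the scatter). For compound 4, the estimated value is 18000 nM, with an expected range from 8000 nM to 36000 nM.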

Compound 4, half-maximal inhibitory concentration: 18000 nM
Compound 4: middle estimate and measured number agree at the digits printed, within the range that was stated.
By their numbers in this assay, from the lowest: compound 3; then compounds 4, 2 and 1 (each within the scatter of the next).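

In this assay, a small carbon group on this aromatic carbon behaves like the two earlier groups: methyl in place of bromo barely moves the number (a 1.1-fold lower number from compound 2 to compound 4 (0.05 log units; within the scatter)), and neither does methyl in place of sulfamoyl (a 1.2-fold lower number from compound 1 to compound 4 (0.09 log units; within the scatter)). Bromo, sulfamoyl and methyl therefore lie within the scatter of one another here, so these exchanges give no order among the three groups. No measurement at hand accounts for this. From the compounds shown here alone, whether an amine, a carboxylic acid or a longer chain on this carbon would move the number beyond the scatter remains open.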